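The source may hold more compounds than are shown below. What is called first, only, known or untested is meant among the compounds shown, and "the series" means these compounds.

The three measured compounds, each with its reading in an ADME assay on MT4 cells (Homo sapiens) for cytotoxicity, read by MTT assay; on this read-out higher numbers stand for lower toxicity in this test and lower numbers for higher toxicity in this test:

compound 1, `COc1cccc2c1c(C(=O)/C=C(\O)C(=O)O)cn2Cc1cccc(F)c1`, gives 65800 nM;
compound 2, `CCOC(=O)/C(O)=C/C(=O)c1cn(Cc2ccc(F)c(F)c2F)c2cccc(OC)c12`, gives 42700 nM;
compound 3, `CCOC(=O)/C(O)=C/C(=O)c1cn(Cc2ccc(F)cc2F)c2cccc(OC)c12`, gives 65500 nM.

Compound 1 sits among these three within a narrow band: its number and that of compound 3 are essentially the same, and the gap from compound 2 to compound 1 is within the usual scatter, so no ordering can be read into the set. Compound 4, `COc1cccc2c1c(C(=O)/C=C(\O)C(=O)O)cn2Cc1cccc(F)c1F`, arises from compound 1 by fluoro in place of hydrogen on an aromatic carbon, so that 3-fluorobenzyl becomes 2,3-difluorobenzyl. For the measured compounds named here, the only measured step bearing on this is the one from compound 2 to compound 3, which runs the other way, removing a fluoro from the benzyl ring, and gives a 1.5-fold higher number from compound 2 to compound 3 (0.19 log units; within the scatter). Adding a fluoro at a different place on the same ring is therefore expected to move this assay by nothing beyond the scatter, with a step of a 1.1-fold lower number from compound 1 to compound 4 (0.04 log units; within the scatter) from compound 1 to compound 4. Compound 4 is accordingly estimated at 60000 nM, between 30000 nM and 120000 nM.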

Compound 4, half-maximal cytotoxic concentration: 17500 nM
Estimate against measurement, compound 4: 3.4-fold (0.54 log units) above; measured number below the stated range.
By their numbers in this assay, from the lowest: compound 4; then compounds 2, 3 and 1 (each within the scatter of the next).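

In this assay, for the compounds shown here, the change from 3-fluorobenzyl to 2,3-difluorobenzyl gives the first step in the set that lies beyond the scatter: a 3.8-fold lower number from compound 1 to compound 4 (0.58 log units; beyond the scatter). A single added fluoro on this ring, ortho to a fluoro group and ortho to a large group, is thus enough to shift this read-out towards higher toxicity in this test. The earlier step on the other core stayed within the scatter, but the gap between the two steps does not exceed what two such steps can show, so no difference between the cores can be claimed: the same change on two cores in this assay, a 1.5-fold higher number (0.19 log units; within the scatter) from compound 2 to compound 3 and a 3.8-fold higher number (0.58 log units; beyond the scatter) from compound 4 to compound 1, 2.5-fold (0.39 log units) apart, within the scatter of two such steps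

On these data alone, it remains open whether a chloro or a methyl group at this place would lower the number as well. Also open, as far as these compounds go, is whether the 2,3-difluorobenzyl group would give the same result with an ethyl ester in place of the carboxylic acid.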